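Plasma stability notes: carboxylic acid replacing fluorinated aryl group

The source may hold more compounds than are shown below. What is called first, only, known or untested is meant among the compounds shown, and "the series" means these compounds.

The series is followed in an ADME assay on a cell-free system (plasma, Rattus norvegicus) for metabolic stability, read by LC-MS, with a stated time of 1 h, at 37 degrees C, tested at 100 uM; a lower number here means that less of the compound is left, a higher number that more of the compound is left. Among the measured compounds shown here, compound 1, `O=C(O)c1cc(-c2cccc(COc3ccc4c(=O)n(C5CCC5)sc4c3)c2)ccc1Cl`, carries a carboxylic acid on its outer ring and is the only member with a number so far: in this assay compound 1 gives 91%. Compound 2, `O=C1c2ccc(OCc3cccc(-c4ccc(C(F)(F)F)cc4F)c3)cc2CN1C1CCCC1`, has "not determined" (no result reported) in this assay, so its standing cannot be placed on any number; nothing is known of how it behaves here. Compound 3, `COc1ccc(C(=O)O)cc1-c1cccc(COc2ccc3c(c2)CN(C2CCCC2)C3=O)c1`, is the next member to be tested. The change from compound 2 to compound 3 is 5-carboxy-2-methoxyphenyl in place of 2-fluoro-4-(trifluoromethyl)phenyl on an aromatic carbon. For the measured compounds named here, no measured step between neighbours exists in this assay, so the size of the move from compound 2 to compound 3 cannot be read from the data. The expectation for compound 3 rests on compound 1 alone, because compound 1 gives 91% and likewise carries a carboxylic acid on the outer ring. Compound 3 is therefore expected to give about 88%, with a range of 70% to 100%.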

Compound 3, percent of the compound remaining: 100%
Estimate against measurement, compound 3: 12 percentage points below; the range from low to high includes it.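

No step can be read between compound 2 and compound 3 in this assay, where compound 3 gives 100%. The compounds shown leave open what replacing 2-fluoro-4-(trifluoromethyl)phenyl with 5-carboxy-2-methoxyphenyl does to the percent remaining. No evidence at hand bears on this result.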